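The source may report more compounds than this note shows. Statements on the series, on what has been measured and on what is new or still open speak of the compounds shown alone.

Working notes on the series in a functional assay on Right cardiac atrium for agonist activity at histamine H2 receptor (Cavia porcellus), with a stated time of 30 min, in the presence of a further agent that is not named here; on this read-out lower numbers stand for an effect already at smaller amounts and higher numbers for an effect only at larger amounts of compound.

Three compounds carry numbers. Compound 1 `Cc1nc(N)sc1CCCN/C(N)=N/C(=S)NC(c1ccccc1)c1ccccc1` gives 66.1 nM. Compound 2 `CCCCCNC(=O)/N=C(\N)NCCCc1sc(N)nc1C` gives 5.75 nM. Compound 3 `Cc1nc(N)sc1CCCN/C(N)=N/C(=S)N[C@@H](C)c1ccccc1` gives 224 nM. Among these three, compound 2 stands at the lowest number; the gaps to compound 1 and to compound 3 both lie beyond the scatter, so compound 2 is the most potent of the three measured. Going by the values given here, no pair among them differs in a single place, so no step between measured compounds can be read off.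

Compound 4 `Cc1nc(N)sc1CCCN/C(N)=N/C(=O)NC(C)c1cccs1` has not yet been measured. Its difference from compound 2 is 1-(thiophen-2-yl)ethyl in place of pentyl on an amide-type nitrogen. The two compounds that carry a ring on the terminal nitrogen, compound 1 and compound 3, sit at higher numbers than compound 2, but both also lack the carbonyl that compound 2 and compound 4 share, so that comparison is only indirect.

An upward shift in this assay is expected on going to compound 4, beyond the scatter but smaller than the gap from compound 2 to compound 3: the expected step is a 5.2-fold higher number from compound 2 to compound 4 (0.72 log units; beyond the scatter). For compound 4 the estimate is 30 nM, with a range from 8 nM to 150 nM.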

Compound 4, half-maximal effective concentration: 10 nM
Beside the measured number, compound 4's estimate is 3.0-fold (0.48 log units) above it, within the range that was stated.
By their numbers in this assay, from the lowest: compounds 2 and 4 (each within the scatter of the next); then compound 1; then compound 3.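

In this assay, the exchange of pentyl for 1-(thiophen-2-yl)ethyl on the amide-type nitrogen gives a 1.7-fold higher number from compound 2 to compound 4 (0.24 log units; within the scatter) and so leaves the two compounds indistinguishable on this read-out. Going by these compounds alone, this is the first single-place comparison: an open chain and a group carrying one five-membered aromatic ring with a sulfur atom stand level at this position, something that compounds 1 and 3 could not show, as each differs from compound 2 in more than one place. No measurement at hand offers an explanation for this result.

On these data alone, it remains open how far this position extends, for example whether an octyl chain or a cyclohexyl group on the same nitrogen would keep the number within the scatter of compound 2. Also open, as far as these compounds go, is the contribution of the carbonyl: compounds 1 and 3 carry a thiocarbonyl together with other terminal groups, whereas 1-phenylethyl on the carbonyl form would differ in a single place from both compound 3 and compound 4.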